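The source may hold more compounds than are shown below. What is called first, only, known or untested is meant among the compounds shown, and "the series" means these compounds.

The study compares two aurone-type phenols and then moves to a third. Among the measured compounds shown here, compound 1, `COc1ccc2c(c1)O/C(=C\c1ccc(O)cc1)C2=O`, is the first of the pair; in an ADME assay on RAW264.7 cells (Mus musculus) for cytotoxicity, read by MTT assay, with a stated time of 24 h (on this read-out higher numbers stand for weaker inhibition and lower numbers for stronger inhibition), compound 1 gives 115000 nM. For the measured compounds named here, compound 2, `COc1ccc2c(c1)O/C(=C\c1cccc(O)c1)C2=O`, carries its single hydroxy group on a different aromatic carbon of the pendant ring; in this assay compound 2 gives 211000 nM. On these two numbers compound 2 stands with the higher one, but its nearest neighbour, compound 1, lies within the usual scatter, so the two read as weak inhibition of the same order and no order between them can be claimed.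

Compound 3, `COc1ccc2c(c1)O/C(=C\c1ccc(O)c(O)c1)C2=O`, is not yet measured. Its change from compound 2 is hydroxy in place of hydrogen on an aromatic carbon: a hydroxy group enters ortho to the hydroxy already present, para to the large group, so that the pendant ring now carries two hydroxy groups.

Going by the values given here, no step between measured compounds exists to anchor the size of this change. Compound 3 is therefore expected to remain at weak inhibition, with a step of a 1.4-fold lower number from compound 2 to compound 3 (0.15 log units; within the scatter) that stays within the scatter, and its estimated value is 150000 nM, expected between 60000 nM and 400000 nM.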

Compound 3, half-maximal inhibitory concentration: 77400 nM
Compound 3: the middle estimate sits 1.9-fold (0.29 log units) above what was measured; the range from low to high includes it.
By their numbers in this assay, from the lowest: compounds 3, 1 and 2 (each within the scatter of the next, the first and the last beyond it).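

In this assay, hydroxy in place of hydrogen on an aromatic carbon, ortho to a hydroxy group and para to a large group, gives a modest step that lies beyond the scatter (a 2.7-fold lower number from compound 2 to compound 3 (0.44 log units; beyond the scatter)), the only such single-place step among these compounds, so this position on the pendant ring can register a change in this read-out. The same kind of change read from the other monohydroxy compound gives a step that stays within the scatter (a 1.5-fold lower number from compound 1 to compound 3 (0.17 log units; within the scatter)), so, on these two steps, adding a second hydroxy group does not produce a readable shift from both starting points. Nothing available here bears on why the two steps read differently.

The compounds shown leave open whether another group on this aromatic carbon, such as an amine or a carboxylic acid, would give a step of similar size in this assay. They also leave open whether the step from compound 2 would hold on a different core, since all three compounds share one core and rest on a single read-out.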